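Removing the ring fluorine of a fluorophenyl-pyridine carboxamide

The source may report more compounds than this note shows. Statements on the series, on what has been measured and on what is new or still open speak of the compounds shown alone.

Measured compounds:
compound 1 `COc1cc2c(Oc3ccc(NC(=O)c4cc(-c5ccccc5F)ccn4)cc3F)ccnc2cc1OCCCN1CCCCC1` – 320 nM
compound 2 `COc1cc2c(Oc3ccc(NC(=O)c4cc(-c5ccccc5F)ccn4)cc3F)ccnc2cc1OCCCN1CCN(C)CC1` – 220 nM
compound 3 `COc1cc2c(Oc3ccc(NC(=O)c4cc(-c5ccccc5F)ccn4)cc3F)ccnc2cc1OCCCN1CCCC1` – 230 nM

Three compounds share one core and differ only in the cyclic amine at the end of the three-carbon chain. In a functional assay on HT-29 cells (Homo sapiens) for cytotoxicity, read by MTT assay, with a stated time of 72 h (on this read-out higher numbers stand for weaker inhibition and lower numbers for stronger inhibition), compound 1 gives 320 nM, compound 2 gives 220 nM and compound 3 gives 230 nM. Compound 1 carries the highest of the three numbers, but the gaps are small: a 1.5-fold lower number from compound 1 to compound 2 (0.16 log units; within the scatter) and a 1.4-fold lower number from compound 1 to compound 3 (0.14 log units; within the scatter), and likewise a 1.0-fold higher number from compound 2 to compound 3 (0.02 log units; within the scatter). None of the three amines can be told apart on these figures.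

Compound 4 `COc1cc2c(Oc3ccc(NC(=O)c4cc(-c5ccccc5)ccn4)cc3F)ccnc2cc1OCCCN1CCCCC1` is not yet measured. It departs from compound 1 at a different place: hydrogen in place of fluoro on an aromatic carbon. Among the measured compounds shown here, no measured step touches this ring; all three known steps exchange the amine at the far end of the chain and each stays within the scatter. There is therefore nothing in the numbers that points to a shift in either direction, and the closest guidance is the flatness of the series itself.

The step from compound 1 to compound 4 is therefore expected to be a 1.1-fold higher number from compound 1 to compound 4 (0.04 log units; within the scatter), a change not beyond the scatter. Compound 4 is estimated to give 350 nM in this assay, with a plausible range from 150 nM to 800 nM.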

Compound 4, half-maximal inhibitory concentration: 270 nM
Compound 4: the middle estimate sits 1.3-fold (0.11 log units) above what was measured; the range from low to high includes it.
By their numbers in this assay, from the lowest: compounds 2, 3, 4 and 1 (each within the scatter of the next).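

In this assay, the change from 2-fluorophenyl to phenyl, with hydrogen in place of fluoro on an aromatic carbon, gives a 1.2-fold lower number from compound 1 to compound 4 (0.07 log units; within the scatter). This is the first step shown at this ring rather than at the amine on the chain, and it shows that, with piperidin-1-yl at the end of the chain, the fluoro group ortho to a large group can give way to hydrogen without a difference that can be told from the scatter of repeated measurements, so that this end of the molecule, like the amine end, shows no measurable step so far. No information is available on what lies behind this small step.

The compounds shown leave open whether hydrogen in place of fluoro would read the same way with 4-methylpiperazin-1-yl or pyrrolidin-1-yl at the end of the chain, since this one pair carries only piperidin-1-yl. They also leave open whether a larger or differently built group at the same place on this ring, such as methoxy, trifluoromethyl, an amine or a carboxylic acid, would produce a step beyond the scatter.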